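A few compounds are considered here, and "the series" means these few. Any claim that something is new, unique, unknown or untested is made for them only; others in the source may bear on it.

Compound 1 `Cc1noc(-c2nc(C)c3c(c2N)C(=O)N(Cc2ccc(Br)cc2)C3=O)n1`: < 5000 nM
Compound 2 `Cc1noc(-c2nc(C)c3c(c2N)C(=O)N(Cc2ccc(Cl)cn2)C3=O)n1`: < 5000 nM
Compound 3 `Cc1noc(-c2nc(C)c3c(c2N)C(=O)N(Cc2ccc(S(C)(=O)=O)cc2)C3=O)n1`: < 5000 nM

Each of these three entries is a limit of the assay and not a number.

In a physicochemical assay for solubility, using the shake flask method, in simulated intestinal fluid, measured as kinetic solubility, with a stated time of 2 h, at 25 degrees C, at pH 6.5 (on this read-out higher numbers stand for higher solubility and lower numbers for lower solubility), compound 3 gives < 5000 nM, which is a limit. It therefore has no exact place among the three compounds, and the overall picture is the limit of < 5000 nM in this assay, at which 3 of the 3 values shown sit.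

Compound 4 `Cc1noc(-c2nc(C)c3c(c2N)C(=O)N(Cc2ccc(C(N)=O)cc2)C3=O)n1` keeps the shared core and the saturated chain carbon of compound 3, but has carbamoyl in place of methylsulfonyl on an aromatic carbon. The change goes from 4-(methylsulfonyl)phenyl to 4-carbamoylphenyl.

Going by the values given here, three measured steps bear on this change. The nearest is a step that the two limits leave unreadable from compound 1 to compound 3, which changes the same place on the ring. The others are a step that the two limits leave unreadable from compound 2 to compound 3 and a step that the two limits leave unreadable from compound 1 to compound 2. None of them has a readable size, so none gives a size or a direction to carry over to compound 4.

Compound 4 is expected to be reported as a limit too because of the limit of < 5000 nM in this assay, at which 3 of the 3 values shown sit. The estimated step is a step that the limit leaves unreadable from compound 3 to compound 4, and no change beyond the usual scatter is expected in either direction. For compound 4 the expected value is 3000 nM, with an estimated range from 1000 nM to 5000 nM.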

Compound 4, solubility: < 5000 nM
Compound 4: only a limit was reported (the forecaster's own chance of this, stated with the estimate: 85%); the middle value is on the limit's open side.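

In this assay compound 4 gives < 5000 nM, which is a limit of the assay and not a number. Its steps from compound 1, compound 2 and compound 3 cannot be read. The compounds shown leave open where any true value lies and whether any of these changes shifts the read-out at all: the limit of < 5000 nM in this assay, at which 4 of the 4 values shown sit.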